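A few compounds are considered here, and "the series" means these few. Any claim that something is new, unique, unknown or untested is made for them only; others in the source may bear on it.

Measured so far:
Compound 1, `CC(=O)Nc1nccc2ncc(-c3cnn(C)c3)cc12`: > 50000 nM
Compound 2, `COc1ccc(C(=O)Nc2nccc3ncc(-c4cnn(C)c4)cc23)cc1`: > 50000 nM

In a functional assay on HeLa cells (Homo sapiens) for antiproliferative activity, read by MTT assay, with a stated time of 48 h (a higher number here means a weaker inhibitor, a lower number a stronger inhibitor), compound 2 reaches only a limit, > 50000 nM. Compound 1 likewise reaches only a limit, > 50000 nM. Among the compounds with values here, the one measured step, a step that the two limits leave unreadable from compound 1 to compound 2, is therefore not readable, and both values sit at the limit of > 50000 nM in this assay, at which 2 of the 2 values shown sit.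

Compound 3, `Cn1cc(-c2cnc3ccnc(NC(=O)c4cccnc4)c3c2)cn1`, differs from compound 2 by pyridin-3-yl in place of 4-methoxyphenyl on a carbonyl carbon. The measured step changed the same position but gives no readable size, so no direction can be drawn from it. The step that the limit leaves unreadable from compound 2 to compound 3 is expected to be none beyond the scatter. Compound 3 is estimated at 80000 nM, with a range of 20000 nM to 300000 nM.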

Compound 3, half-maximal inhibitory concentration: > 50000 nM
Compound 3: no number, only a limit (the forecaster's own chance of this, stated with the estimate: 80%); the middle value lies beyond the limit too.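

No step among compound 1, compound 2 and compound 3 can be read, because each value is only a limit: the limit of > 50000 nM in this assay, at which 3 of the 3 values shown sit.

The compounds shown leave open how strongly each acts in this assay, and whether methyl, 4-methoxyphenyl or pyridin-3-yl on the carbonyl carbon makes any difference there.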